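Cytotoxicity notes on a fused-core amide series

The source may hold more compounds than are shown below. What is called first, only, known or untested is meant among the compounds shown, and "the series" means these compounds.

Measured so far:
compound 1, `COc1ccc(Nc2ncnc3c(=N)n(NC(=O)c4ccccc4)cnc23)cc1` — 2.12 ug/mL
compound 2, `N=c1c2ncnc(Nc3ccc(F)cc3)c2ncn1NC(=O)c1ccncc1` — 1.53 ug/mL

Both compounds were run in an ADME assay on Vero cells (Chlorocebus sabaeus) for cytotoxicity; a higher number here means that more compound is needed for the effect, a lower number that less compound is needed. Compound 2 gives the lowest of the two numbers in this assay, with compound 1 as its nearest neighbour, and the gap between the two lies within the usual scatter, so no order between them can be read from these values. Going by the values given here, the two compounds differ in more than one place, so no single structural step connects them.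

The next compound in the series is compound 3, `N=c1c2ncnc(Nc3ccc(F)cc3)c2ncn1NC(=O)c1ccccc1`, to be measured in this assay. It is reached from compound 2 by one change: phenyl in place of pyridin-4-yl on a carbonyl carbon. Among the compounds with values here, no measured pair shows this change on its own, so there is nothing to set its size. With nothing beyond the scatter between compound 1 and compound 2 either, the expected step from compound 2 to compound 3 is a 1.2-fold higher number from compound 2 to compound 3 (0.07 log units; within the scatter), that is, no shift beyond the scatter in either direction. Compound 3 is therefore estimated at 1.8 ug/mL in this assay, with a range from 0.8 ug/mL to 4 ug/mL.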

Compound 3, half-maximal effective concentration: 3.05 ug/mL
Compound 3: the middle estimate sits 1.7-fold (0.23 log units) below what was measured; the range from low to high includes it.
By their numbers in this assay, from the lowest: compounds 2, 1 and 3 (each within the scatter of the next).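

Going by these compounds alone, at the carbonyl carbon of the amide, phenyl in place of pyridin-4-yl gives a 2.0-fold higher number from compound 2 to compound 3 (0.30 log units; within the scatter) in this assay, so the first direct reading of this change, in which a ring nitrogen and its hydrogen-bond acceptor leave, stays within the scatter even though it reaches the edge of what repeated measurements allow. The series also gains a readable step at a second place, since fluoro in place of methoxy on an aromatic carbon gives a 1.4-fold higher number from compound 1 to compound 3 (0.16 log units; within the scatter), again within the scatter, and neither change separates the compounds in this assay. Nothing available bears on why these compounds take the values they do.

As far as these compounds go, it remains open whether a group of a different kind on the carbonyl carbon, such as a saturated ring amine, a carboxylic acid or a longer alkyl chain, would move the number beyond the scatter. From the compounds shown here alone, it is equally open whether the step from pyridin-4-yl to phenyl keeps its size with methoxy instead of fluoro on the aromatic carbon, as it has been read only with fluoro there.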